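The source may report more compounds than this note shows. Statements on the series, on what has been measured and on what is new or still open speak of the compounds shown alone.

Two compounds share one core, each carrying a methoxycarbonyl group and an aromatic ring on its nitrogen. Compound 1 `COC(=O)c1nc(C)n(-c2cccc(C(F)(F)F)c2)n1` bears a methyl group and a phenyl ring carrying a trifluoromethyl group. In a functional assay on NPC-TW01 cells (Homo sapiens) for inhibition, read by MTT assay, with a stated time of 72 h (on this read-out higher numbers stand for weaker inhibition of growth and lower numbers for stronger inhibition of growth), compound 1 gives > 100000 nM, which is a limit of the assay and not a number, as the limit of > 100000 nM in this assay, at which 1 of the 2 values shown sits, records. Compound 2 `COC(=O)c1nc(C2CC2)n(-c2ccc(F)cc2)n1` carries a cyclopropyl group and a phenyl ring carrying fluorine. In this assay, for the measured compounds named here, compound 2 gives 95900 nM; this is the only actual number among the values at hand, so compound 2 is the sole point of reference. Compound 3 `COC(=O)c1nc(-c2ccsc2)n(-c2ccc(F)cc2)n1` has not yet been measured. It differs from compound 2 by thiophen-3-yl in place of cyclopropyl on an aromatic carbon. Going by the values given here, no measured pair shows what such a change does here, and compound 2 with its 95900 nM sits near the edge of the measurable range. A step no larger than the usual scatter, in no firm direction, is therefore expected, namely a 1.1-fold lower number from compound 2 to compound 3 (0.03 log units; within the scatter). For compound 3 the estimated value in this assay is 90000 nM, ranging from 25000 nM to 300000 nM.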

Compound 3, concentration for 50% growth inhibition: 10700 nM
Beside the measured number, compound 3's estimate is 8.4-fold (0.92 log units) above it, outside the stated range (below it).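

In this assay this position turns out to respond clearly to what it carries: putting thiophen-3-yl in place of cyclopropyl on the aromatic carbon between two ring nitrogen atoms gives a 9.0-fold lower number from compound 2 to compound 3 (0.95 log units; beyond the scatter), and a lower number here means stronger inhibition of growth. Compound 1 and compound 2 differ in more than one place, so they could say nothing about this position alone, whereas compound 2 and compound 3 form a pair that differs only here and shows that the group at this carbon can shift the read-out beyond the usual scatter. Nothing at hand explains why the step has this size.

On these data alone, it remains open whether the stronger inhibition goes with the sulfur, with the aromatic ring or simply with the larger group, and a phenyl ring, a furan-3-yl ring or an amine on the same carbon would help to separate these. Also open, as far as these compounds go, is whether the same change would hold with the trifluoromethyl-bearing phenyl ring of compound 1, or with a carboxylic acid in place of the methoxycarbonyl group.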